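Moving the Pyridine Nitrogen in a Chemokine Receptor Antagonist

The compounds below may be only part of what the source reports. "The series", "measured", "known", "first", "only" and "open" are said of these compounds alone.

Two measured compounds share one core and differ only in the pyridine ring attached to a saturated ring carbon. Compound 1 `O=C1CCC(c2ccccn2)(C2CCN(Cc3ccc(Br)cc3)CC2)C(=O)N1` carries pyridin-2-yl, and in a functional assay on CHO cells for antagonist activity at C-X-C chemokine receptor type 3 (Homo sapiens), read by GTPgammaS binding, with a stated time of 30 min (on this read-out lower numbers stand for stronger inhibition and higher numbers for weaker inhibition), compound 1 gives 500 nM. Compound 2 `O=C1CCC(c2cccnc2)(C2CCN(Cc3ccc(Br)cc3)CC2)C(=O)N1` carries pyridin-3-yl, and in this assay compound 2 gives 1000 nM. The step of a 2.0-fold higher number from compound 1 to compound 2 (0.30 log units; within the scatter) separates them. Of the two numbers, compound 2 has the higher one, by a gap that lies within the scatter.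

Compound 3 `O=C1CCC(c2ccncc2)(C2CCN(Cc3ccc(Br)cc3)CC2)C(=O)N1` completes the set of ring-nitrogen positions: pyridin-4-yl in place of pyridin-3-yl on a saturated ring carbon. Within the data shown here, only one measured step speaks to such a move, a 2.0-fold higher number from compound 1 to compound 2 (0.30 log units; within the scatter), which also shifted the nitrogen by one position and stayed within the scatter. On that basis no step beyond the scatter is expected here either, and the estimated step is no change at the digits printed from compound 2 to compound 3 (within the scatter). Compound 3 is therefore expected to give 1000 nM, with a range from 400 nM to 3000 nM.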

Compound 3, half-maximal inhibitory concentration: 630 nM
Compound 3: middle estimate off by 1.6-fold (0.20 log units), on the high side; measured number inside the range.
By their numbers in this assay, from the lowest: compounds 1, 3 and 2 (each within the scatter of the next).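

With pyridin-4-yl in place, all three ring-nitrogen positions of the pyridine on this saturated ring carbon now have a number in this assay, and both new comparisons stay inside the usual scatter (a 1.6-fold lower number from compound 2 to compound 3 (0.20 log units; within the scatter); a 1.3-fold higher number from compound 1 to compound 3 (0.10 log units; within the scatter)). The first pair alone could say only that one shift of the nitrogen made no readable difference, whereas the complete set shows that no placing of the nitrogen can be told apart from the others here, so compounds 1, 2 and 3 have to be treated as equals in this test. Nothing available explains why the three numbers lie so close together.

As far as these compounds go, what remains open is whether the ring nitrogen matters at all, which a plain phenyl ring at this carbon would test, and whether a pyrimidin-2-yl ring or an added methoxy group on the pyridine would move the number beyond the scatter. From the compounds shown here alone, all three compounds also keep the bromine of the shared core, so it is unknown whether the same indifference to the nitrogen position would hold with a chlorine there instead.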